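Oxadiazole in Place of Methoxy on a Biaryl Amide

This account rests on a few compounds, and the source may have more. Where it says the series, first, only, none or still open, it means among the compounds named here.

Compound 1 `CC(C)N(Cc1cccc(OCCCCCC(=O)O)c1)C(=O)c1ccc(-c2cccc(OCc3ccccc3)c2)cc1`: > 26000 nM
Compound 2 `COc1cccc(-c2ccc(C(=O)N(Cc3cccc(OCCCCCC(=O)O)c3)C(C)C)cc2)c1`: > 20900 nM

In an ADME assay on BJ cells (Homo sapiens) for cytotoxicity, read by CellTiter-Glo and resazurin assay, with a stated time of 72 h (a higher number here means that more compound is needed for the effect, a lower number that less compound is needed), compound 1 gives > 26000 nM, which is a limit of the assay and not a number. Compound 1 sits at the limit of > 26000 nM in this assay, at which 1 of the 2 values shown sits. Compound 2 gives > 20900 nM, again only a limit. Compound 2 sits at the limit of > 20900 nM in this assay, at which 1 of the 2 values shown sits. Because both readings are limits, the step that the two limits leave unreadable from compound 1 to compound 2 cannot be read, and compound 2 stands at a limit with no measured number to place it against.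

Compound 3 `Cc1nnc(-c2cccc(-c3ccc(C(=O)N(Cc4cccc(OCCCCCC(=O)O)c4)C(C)C)cc3)c2)o1` differs from compound 2 by 5-methyl-1,3,4-oxadiazol-2-yl in place of methoxy on an aromatic carbon. Going by the values given here, the only measured step, from compound 1 to compound 2, bears on a different position and is itself unreadable, so it gives no direction for the new change. No step beyond the scatter is expected in this assay; the step that the limit leaves unreadable from compound 2 to compound 3 is estimated to be flat. Compound 3 is therefore expected to give about 30000 nM, within 12000 nM to 80000 nM, most likely reported once more as a limit.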

Compound 3, half-maximal effective concentration: > 26000 nM
Compound 3 ended at the assay's limit; the forecaster's own chance of this, stated with the estimate: 75%; the middle value does not contradict the limit.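

In this assay compound 3 gives > 26000 nM, a limit of the assay and not a number. Going by these compounds alone, no step among compound 1, compound 2 and compound 3 can be read. The compounds shown leave open whether 5-methyl-1,3,4-oxadiazol-2-yl in place of methoxy shifts the half-maximal effective concentration at all.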